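Swapping the ethynyl for a piperidinylcarbonyl on a shared core

This account rests on a few compounds, and the source may have more. Where it says the series, first, only, none or still open, it means among the compounds named here.

Measured compounds and their values:
- compound 1, `C#Cc1cccc(-n2ccc3cc(OC)cc(OC)c3c2=O)c1`: 7130 nM
- compound 2, `COc1cc(OC)c2c(=O)n(Cc3ccccc3)ccc2c1`: 3880 nM
- compound 3, `C#Cc1cccc(-n2ccc3cc(OC)cc(O)c3c2=O)c1`: 4440 nM

Three compounds with a shared core were tested in a functional assay on A-431 cells (Homo sapiens) for antiproliferative activity, read by MTT assay, with a stated time of 72 h; a higher number here means a weaker inhibitor, a lower number a stronger inhibitor. Compound 1 gives 7130 nM, compound 2 gives 3880 nM and compound 3 gives 4440 nM. Compound 3 sits second highest of the three numbers, nearest to compound 2 and furthest from compound 1, but all three values lie within the scatter of one another, so no order among them can be read from these data.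

Compound 4, `COc1cc(O)c2c(=O)n(-c3cccc(C(=O)N4CCCCC4)c3)ccc2c1`, has not yet been measured in this assay. It differs from compound 3 in one place: (piperidin-1-yl)carbonyl in place of ethynyl on an aromatic carbon.

Within the data shown here, the only single-point step that has been measured, a 1.6-fold lower number from compound 1 to compound 3 (0.21 log units; within the scatter), concerns the oxygen on the aromatic ring of the core and says nothing about the group on the other ring. Compound 2 carries a different substituent there, but it differs from compound 3 in more than one place, so its value is no guide to this exchange. Among the measured compounds shown here, no measured step bears on the change from ethynyl to (piperidin-1-yl)carbonyl, and the expectation for this assay therefore rests on compound 3 alone.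

On that basis compound 4 is expected to give about 4500 nM, within a wide range from 1000 nM to 20000 nM, which corresponds to an expected step of a 1.0-fold higher number from compound 3 to compound 4 (0.01 log units; within the scatter), no larger than the scatter.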

Compound 4, half-maximal inhibitory concentration: 2250 nM
Beside the measured number, compound 4's estimate is 2.0-fold (0.30 log units) above it; measured number inside the range.
By their numbers in this assay, from the lowest: compounds 4, 2, 3 and 1 (each within the scatter of the next, the first and the last beyond it).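

In this assay, among these compounds, the exchange on this aromatic carbon gives a 2.0-fold lower number from compound 3 to compound 4 (0.30 log units; within the scatter) and is the first measured step at this position, as the earlier step concerned only the oxygen on the core. The ethynyl, with 2 heavy atoms, no ring and no hydrogen-bond acceptor, gives way to a (piperidin-1-yl)carbonyl with 8 heavy atoms, a six-membered non-aromatic ring and 1 hydrogen-bond acceptor, so a much larger group at this place still leaves the number within the scatter of compound 3, and no direction can be read from this single step. Nothing available explains this outcome.

The compounds shown leave open whether other groups on this carbon, such as a carboxylic acid, a simple amine or an open-chain amide without the piperidine ring, would move the number beyond the scatter. They also leave open whether the same exchange would give a similar step on the core of compound 1, which carries a methoxy group where compound 3 carries a hydroxyl group.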